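The source may hold more compounds than are shown below. What is called first, only, known or untested is meant among the compounds shown, and "the series" means these compounds.

Measured so far:
- compound 1, `CC(C)(C)Cc1csc(N)c1C(=O)c1ccc(Cl)cc1`: 1%
- compound 2, `CC(C)(C)Cc1c(-c2ccoc2)sc(N)c1C(=O)c1ccc(Cl)cc1`: 1%
- compound 3, `CC(C)(C)Cc1c(-c2c(F)cccc2F)sc(N)c1C(=O)c1ccc(Cl)cc1`: 1%

In an assay on CHO cells for displacement of a labelled ligand from adenosine receptor A1 (Homo sapiens), read by scintillation counting, tested at 10 uM (on this read-out lower numbers stand for less inhibition and higher numbers for more inhibition at the one concentration tested (going by the name of the read-out)), compound 3 stands level with compound 1 and compound 2 at the digits shown. The steps of no change at the digits printed from compound 1 to compound 3 (within the scatter) and no change at the digits printed from compound 2 to compound 3 (within the scatter) both sit within the scatter, as does no change at the digits printed from compound 1 to compound 2 (within the scatter); across the three aryl variations at this ring carbon, the read-out in this assay has not moved.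

Compound 4, `COc1ccccc1-c1sc(N)c(C(=O)c2ccc(Cl)cc2)c1CC(C)(C)C`, is the next point in the same series. Relative to compound 3 the change is 2-methoxyphenyl in place of 2,6-difluorophenyl on an aromatic carbon.

Going by the values given here, the steps that bear on this are those that already swapped the group at this ring carbon: no change at the digits printed from compound 1 to compound 3 (within the scatter) and no change at the digits printed from compound 2 to compound 3 (within the scatter), both flat. Nothing in the measured set shows that a substituent at this position shifts the signal in this assay. For compound 4 the expected step is therefore a number 1 percentage points higher from compound 3 to compound 4 (within the scatter). Compound 4 is therefore estimated at 2% in this assay, with a range of -6% to 12%.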

Compound 4, a percentage reported as inhibition, at one concentration (the size of the read-out at that concentration, not a potency): 1%
Estimate against measurement, compound 4: 1 percentage points above; measured number inside the range.
By their numbers in this assay, from the lowest: compounds 1, 2, 3 and 4 (each within the scatter of the next).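

In this assay, 2-methoxyphenyl brings an oxygen and a hydrogen-bond acceptor that 2,6-difluorophenyl lacks, yet the read-out stays put: no change at the digits printed from compound 3 to compound 4 (within the scatter). The same holds against furan-3-yl, no change at the digits printed from compound 2 to compound 4 (within the scatter), and against plain hydrogen, no change at the digits printed from compound 1 to compound 4 (within the scatter), so the four groups on this aromatic carbon next to the ring sulfur give no separation at the digits printed, now with an acceptor-bearing six-membered aryl group included. No supporting data bear on this flat result.

On these data alone, whether an amine or a carboxylic acid on this carbon would lift the signal remains open. Also open is whether a longer chain in place of the neopentyl group, or a change at the (4-chlorophenyl)carbonyl group, would move it, since every compound shown shares both.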